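The compounds below may be only part of what the source reports. "The series", "measured", "known", "first", "only" and "open" are said of these compounds alone.

Compound 2 `CCCN(CCC)c1nc(C(F)(F)F)ccc1CNC(=O)C(C)c1ccc(NS(C)(=O)=O)c(F)c1` stands lowest of the two numbers in a functional assay on CHO-K1 cells for antagonist activity at transient receptor potential cation channel subfamily V member 1 (Homo sapiens), read by FLIPR (a higher number here means a weaker inhibitor, a lower number a stronger inhibitor), where compound 2 gives 0.2 nM. Its nearest neighbour is compound 1 `CC(C(=O)NCc1ccc(C(F)(F)F)nc1NCc1ccc(Cl)cc1)c1ccc(NS(C)(=O)=O)c(F)c1`, which in this assay gives 65.7 nM. Among the compounds with values here, the only measured step, a 330-fold lower number from compound 1 to compound 2 (2.52 log units; beyond the scatter), arose from dipropylamino in place of (4-chlorobenzyl)amino on an aromatic carbon. Compound 3 `CC(C(=O)NCc1ccc(C(F)(F)F)nc1N1CCCCC1C)c1ccc(NS(C)(=O)=O)c(F)c1` carries the change (2-methylpiperidin-1-yl in place of dipropylamino on an aromatic carbon). Within the data shown here, this exchanges one dialkylamino group for another at the same aromatic carbon, and no measured step of that kind exists. Among the measured compounds shown here, the step from compound 1 to compound 2 shows only that the group on this carbon matters greatly, not how two dialkylamino groups compare with each other. The step of a 2.5-fold higher number from compound 2 to compound 3 (0.40 log units; beyond the scatter) is therefore expected to lie within or only slightly beyond the scatter. The estimate for compound 3 in this assay is 0.5 nM, with a range from 0.1 nM to 3 nM.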

Compound 3, inhibition constant: 2.9 nM
Compound 3: middle estimate off by 5.8-fold (0.76 log units), on the low side; the measured number falls inside the stated range.
By their numbers in this assay, from the lowest: compound 2; then compound 3; then compound 1.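

In this assay, a 15-fold higher number from compound 2 to compound 3 (1.16 log units; beyond the scatter) accompanies a change that keeps the same count of heavy atoms but holds them in a six-membered non-aromatic ring, so this aromatic carbon distinguishes between two dialkylamino groups and not only between such groups and (4-chlorobenzyl)amino. Even so, a 23-fold lower number from compound 1 to compound 3 (1.36 log units; beyond the scatter) places both dialkylamino compounds at lower numbers than compound 1, which carries the (4-chlorobenzyl)amino group. Nothing at hand gives a measured reason for either step.

The compounds shown do not separate the contribution of the ring from that of its methyl group, which unsubstituted piperidin-1-yl would address. Going by these compounds, how the number responds to the length of the chains also remains open, for example with diethylamino or dibutylamino at this carbon.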